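Aryl swap on a hydroxyethoxy pyrimidine: what to expect

A few compounds are considered here, and "the series" means these few. Any claim that something is new, unique, unknown or untested is made for them only; others in the source may bear on it.

Compound 1 `COc1ccccc1Oc1c(N)nc(-c2ccc(Cl)cc2)nc1Cl` gives 18800 nM in a functional assay on B16 cells (Mus musculus) for cytotoxicity, read by CCK-8 assay, with a stated time of 24 h; a higher number here means a weaker inhibitor, a lower number a stronger inhibitor. Compound 2 `COc1ccccc1Oc1c(N)nc(-c2cccc(Br)c2)nc1Cl` differs by 3-bromophenyl in place of 4-chlorophenyl on an aromatic carbon and gives 24600 nM, a step of a 1.3-fold higher number from compound 1 to compound 2 (0.12 log units; within the scatter). Compound 3 `COc1ccccc1Oc1c(N)nc(-c2ccc(Cl)cc2)nc1OCCO` differs from compound 1 by 2-hydroxyethoxy in place of chloro on an aromatic carbon. In this assay compound 3 gives 7740 nM, a step of a 2.4-fold lower number from compound 1 to compound 3 (0.39 log units; beyond the scatter). Compound 4 `COc1ccccc1Oc1c(N)nc(-c2cccc(Br)c2)nc1OCCO` has not been measured; it differs from compound 3 by 3-bromophenyl in place of 4-chlorophenyl on an aromatic carbon. This is the same kind of change as from compound 1 to compound 2, though the place differs: meta to a 2-hydroxyethoxy group and para to a 2-methoxyphenoxy group rather than meta to a chloro group. Because a 1.3-fold higher number from compound 1 to compound 2 (0.12 log units; within the scatter) lay within the scatter, the estimated step for compound 4 is a 1.3-fold higher number from compound 3 to compound 4 (0.11 log units; within the scatter), which means compound 4 is expected to give about 10000 nM, between 5000 nM and 22000 nM.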

Compound 4, half-maximal inhibitory concentration: 21900 nM
Estimate against measurement, compound 4: 2.2-fold (0.34 log units) below; measured number inside the range.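

On the hydroxyethoxy core, 3-bromophenyl in place of 4-chlorophenyl gives a 2.8-fold higher number from compound 3 to compound 4 (0.45 log units; beyond the scatter) in this assay and so lies beyond the scatter, yet this step does not stand apart from the earlier one on the chloro core: the same change on two cores in this assay, a 1.3-fold higher number (0.12 log units; within the scatter) from compound 1 to compound 2 and a 2.8-fold higher number (0.45 log units; beyond the scatter) from compound 3 to compound 4, 2.2-fold (0.33 log units) apart, within the scatter of two such steps. Read the other way, 2-hydroxyethoxy in place of chloro on the 3-bromophenyl core gives a 1.1-fold lower number from compound 2 to compound 4 (0.05 log units; within the scatter) and likewise does not stand apart from its earlier step: the same change on two cores in this assay, a 2.4-fold lower number (0.39 log units; beyond the scatter) from compound 1 to compound 3 and a 1.1-fold lower number (0.05 log units; within the scatter) from compound 2 to compound 4, 2.2-fold (0.33 log units) apart, within the scatter of two such steps. This shows no difference between the cores for either change, but one pair per change cannot show that the steps carry over unchanged.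

The compounds shown leave open how 3-chlorophenyl or 4-bromophenyl would compare, which would separate the halogen from its place on the phenyl ring. Also open, from the compounds shown here alone, is how an amine, a carboxylic acid or a longer chain would read in place of the 2-hydroxyethoxy group.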